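The source may hold more compounds than are shown below. What is called first, only, known or untested is meant among the compounds shown, and "the series" means these compounds.

Series notes, shared core, all compounds so far tested in an assay on HEK-293T cells for inhibition of phospholipase A and acyltransferase 4 (Homo sapiens), with stated times of 30 min and 20 min; on this read-out higher numbers stand for weaker inhibition and lower numbers for stronger inhibition. Compound 1 is `O=C(CCc1ccc(Cl)cc1)C(=O)N1CCCCC1`. In this assay compound 1 gives > 10000 nM, which is a limit of the assay and not a number. Compound 2 is `CN(C)C(=O)C(=O)CCc1ccc(Cl)cc1`. In this assay compound 2 gives > 10000 nM, again a limit. Compound 3 is `O=C(CCc1ccc(Cl)cc1)C(=O)N1CC[C@@H](c2ccccc2)C1`. In this assay compound 3 gives > 10000 nM, likewise a limit. Within the data shown here, the one step between compounds that differ in one place, a step that the two limits leave unreadable from compound 1 to compound 2, cannot be read because both ends sit at the limit of > 10000 nM in this assay, at which 3 of the 3 values shown sit. Compound 3 thus stands only at a limit, with no number that would set it apart from compound 1 or compound 2.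

Compound 4 is `O=C(CCc1ccc(Cl)cc1)C(=O)N1CCCC1`. It differs from compound 3 by hydrogen in place of phenyl on a saturated ring carbon, a change at a five-membered non-aromatic ring with one nitrogen. Among the measured compounds shown here, no measured step bears on this change: the only step measured is unreadable, so neither a size nor a direction can be carried over. Compound 4 is therefore expected to stay at the limit of this assay, estimated at 15000 nM with a range of 5000 nM to 50000 nM. The step this estimate implies, a step that the limit leaves unreadable from compound 3 to compound 4, is expected to be none beyond the scatter.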

Compound 4, half-maximal inhibitory concentration: > 10000 nM
Compound 4 ended at the assay's limit; the forecaster's own chance of this, stated with the estimate: 85%; the middle value is on the limit's open side.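

No step from compound 1, compound 2 or compound 3 to compound 4 can be read, because all four compounds sit at one limit, which is not a number: the limit of > 10000 nM in this assay, at which 4 of the 4 values shown sit.

The compounds shown leave open which change to the shared core, if any, would give a readable value in this assay and so allow a step to be sized.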